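The source may report more compounds than this note shows. Statements on the series, on what has been measured and on what is new or still open speak of the compounds shown alone.

Compound 3, `COC(=O)CNC1=CS(=O)(=O)O[C@@]12[C@@H](CO[Si](C)(C)C(C)(C)C)O[C@@H](n1cc(C)c(=O)n(C)c1=O)[C@@H]2O[Si](C)(C)C(C)(C)C`, is the starting point. In a functional assay on HEL cells (Homo sapiens) (a higher number here means that more compound is tolerated, a lower number that less compound is tolerated), compound 3 gives 160000 nM, the highest of the two numbers recorded. Its nearest neighbour is compound 1, `CCOC(=O)NC(=O)NC1=CS(=O)(=O)O[C@@]12[C@@H](CO[Si](C)(C)C(C)(C)C)O[C@@H](n1cc(C)c(=O)n(C)c1=O)[C@@H]2O[Si](C)(C)C(C)(C)C`, which in this assay gives 14000 nM; the two differ at the amine nitrogen only, and the move produced an 11-fold higher number from compound 1 to compound 3 (1.06 log units; beyond the scatter). Compound 2, `Cc1cn([C@@H]2O[C@@H]3COC(=O)[C@]3(OS(C)(=O)=O)[C@H]2O)c(=O)[nH]c1=O`, is recorded in this assay only as a limit, >= 36000 nM, so it contributes no number; this is the limit of >= 36000 nM in this assay, at which 1 of the 3 values shown sits.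

The next compound, compound 4, is `COC(=O)CC(=O)NC1=CS(=O)(=O)O[C@@]12[C@@H](CO[Si](C)(C)C(C)(C)C)O[C@@H](n1cc(C)c(=O)n(C)c1=O)[C@@H]2O[Si](C)(C)C(C)(C)C`. It differs from compound 3 in one place: ((methoxycarbonyl)methyl)carbonyl in place of (methoxycarbonyl)methyl on an amine nitrogen. Within the data shown here, the change puts a carbonyl back onto the amine nitrogen, and the single measured step that bears on it, an 11-fold higher number from compound 1 to compound 3 (1.06 log units; beyond the scatter), went the other way, from a carbonyl-bearing group on that nitrogen to one without. Among the measured compounds shown here, that step was large and beyond the scatter, so the writer expects a step downward for compound 4, though smaller, as the entering group is not the same as the one compound 1 carries. The expected step is a 4.6-fold lower number from compound 3 to compound 4 (0.66 log units; beyond the scatter). Compound 4 is therefore estimated at 35000 nM in this assay, within a range from 9000 nM to 130000 nM.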

Compound 4, half-maximal cytotoxic concentration: 29000 nM
The estimate for compound 4 lay 1.2-fold (0.08 log units) above the measured number; the range from low to high includes it.
By their numbers in this assay, from the lowest: compound 1; then compound 4; then compound 3.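

The step of a 5.5-fold lower number from compound 3 to compound 4 (0.74 log units; beyond the scatter) in this assay shows that placing a carbonyl on this amine nitrogen lowers the number even when the methyl ester group is kept, so the earlier drop seen with compound 1 does not depend on that compound's (ethoxycarbonyl)carbamoyl group alone. The group beyond that carbonyl also counts, since the change a 2.1-fold higher number from compound 1 to compound 4 (0.32 log units; beyond the scatter) leaves the two compounds with a carbonyl on this nitrogen apart by more than the scatter, and compound 3, with no carbonyl there, has the highest number of the three. Nothing measured here explains either step, and the one further result available, a limit for a compound of a different structure, has no bearing on them.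

The compounds shown leave open whether the ester at the end of the chain plays any part in these numbers, which a carboxylic acid in its place or a plain acetyl on the nitrogen would help to settle. They also leave open how a longer chain on this nitrogen, with or without the carbonyl, would behave.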